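Replacing a small aromatic group on a chloropyridine amide

This account rests on a few compounds, and the source may have more. Where it says the series, first, only, none or still open, it means among the compounds named here.

Measured so far in a physicochemical assay for solubility, in phosphate buffer, at pH 7.4; on this read-out higher numbers stand for higher solubility and lower numbers for lower solubility:
compound 1, `CC(=O)N[C@@H]1CCC[C@H](C(=O)Nc2cc(-c3cnc(C)n3C)c(Cl)cn2)C1`: > 1000000 nM
compound 2, `CC(=O)N[C@@H]1CCC[C@H](C(=O)Nc2cc(-c3cnn4c3CC(C)(C)CC4)c(F)cn2)C1`: 160000 nM
compound 3, `CC(=O)N[C@@H]1CCC[C@H](C(=O)Nc2cc(-c3cnn4c3CC(C)(C)C4)c(F)cn2)C1`: 550000 nM

Compound 1 does not give a number in this assay; it is reported only as a limit, (the limit of > 1000000 nM in this assay, at which 1 of the 3 values shown sits). Compound 2 and compound 3, which share the same core, give numbers below that limit, and the two values lie more than the usual scatter apart from each other.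

Compound 4, `CC(=O)N[C@@H]1CCC[C@H](C(=O)Nc2cc(-c3cnc4n3CC(C)(C)C4)c(Cl)cn2)C1`, is not yet measured. It differs from compound 1 in one place, (a group of 10 heavy atoms (8 carbon, 2 nitrogen; one five-membered non-aromatic ring with 1 hetero atom, one five-membered aromatic ring with 2 hetero atoms) in place of a group of 7 heavy atoms (5 carbon, 2 nitrogen; one five-membered aromatic ring with 2 hetero atoms), on an aromatic carbon), so that a larger group takes the position ortho to the chloro group and opposite the ring nitrogen on the shared core.

Within the data shown here, no measured step connects compound 1 to a compound of this kind, and compound 1 itself gives only a limit, so the size of the step is uncertain. Compound 4 is expected to return a number rather than a limit, in the region where compound 2 with 160000 nM and compound 3 with 550000 nM sit. For compound 4 the estimate is 350000 nM, within 100000 nM to 1000000 nM. The expected step is an at least 2.8-fold lower number from compound 1 to compound 4 (0.45 log units; beyond the scatter).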

Compound 4, solubility: 280000 nM
Estimate against measurement, compound 4: 1.3-fold (0.10 log units) above, and the stated range covers the measured number.
By their numbers in this assay, from the lowest: compounds 2, 4 and 3 (each within the scatter of the next, the first and the last beyond it). At a limit, above all of these: compound 1.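

In this assay, putting the larger group, with its one five-membered non-aromatic ring and one five-membered aromatic ring, in place of the 1,2-dimethyl-1H-imidazol-5-yl group gives an at least 3.5-fold lower number from compound 1 to compound 4 (0.55 log units; beyond the scatter). This shows that the read-out at this position, ortho to a chloro group and opposite the ring nitrogen, responds to the change, and that compound 4 gives a number on the core of compound 1, beyond the usual scatter from the limit of compound 1. The true size of the step cannot be read, only its lower bound, because compound 1 is reported as a limit and not as a number: the limit of > 1000000 nM in this assay, at which 1 of the 4 values shown sits.

The compounds shown leave open how the read-out would move if a hydroxyl group or an amine took the place of the two methyl groups on the non-aromatic ring of compound 4. They also leave open what the chloro group itself contributes, since no pair shown differs only by a chloro group against a fluoro group.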